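The source may hold more compounds than are shown below. What is called first, only, known or untested is meant among the compounds shown, and "the series" means these compounds.

Working notes on the series. Compound 2 `Cc1ccc(OCc2cn(-c3ccc(S(=O)(=O)N4CCc5ccccc5C4)cc3)nn2)cc1` has in a functional assay on HepG2 cells (Homo sapiens) for cytotoxicity, read by MTT assay, with a stated time of 48 h (a higher number here means a weaker inhibitor, a lower number a stronger inhibitor), only a limit, > 50 ug/mL, not a number. Compound 1 `Cc1ccccc1OCc1cn(-c2ccc(S(=O)(=O)N3CCc4ccccc4C3)cc2)nn1` likewise reaches in this assay only the limit > 50 ug/mL. Among the compounds with values here, the step that the two limits leave unreadable from compound 1 to compound 2 is therefore unreadable, and the only evidence is the limit of > 50 ug/mL in this assay, at which 2 of the 2 values shown sit. Compound 3 `O=c1cc(OCc2cn(-c3ccc(S(=O)(=O)N4CCc5ccccc5C4)cc3)nn2)c2ccccc2o1` carries a group of 11 heavy atoms (9 carbon, 2 oxygen; one six-membered aromatic ring of carbon only, one six-membered aromatic ring with 1 hetero atom) in place of a group of 7 heavy atoms (7 carbon; one six-membered aromatic ring of carbon only), on an oxygen on a saturated carbon. Within the data shown here, no measured step bears on this change, so no direction beyond the scatter can be read for it. Compound 3 is expected to give 60 ug/mL in this assay, within 20 ug/mL to 200 ug/mL. The expected step is a step that the limit leaves unreadable from compound 2 to compound 3, most likely again a limit.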

Compound 3, half-maximal inhibitory concentration: > 50 ug/mL
Compound 3 was reported as a limit (the forecaster's own chance of this, stated with the estimate: 70%); the middle value does not contradict the limit.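

In this assay compound 3 gives > 50 ug/mL, a limit and not a number, so its steps from compound 1 and from compound 2 cannot be read. The compounds shown leave open whether the groups on the oxygen differ at all in this assay: the limit of > 50 ug/mL in this assay, at which 3 of the 3 values shown sit.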